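Furan for Thiophene on a Shared Pyridine-Free Core

The source may report more compounds than this note shows. Statements on the series, on what has been measured and on what is new or still open speak of the compounds shown alone.

Measured compounds:
compound 1, `Oc1cccc(-c2cc(-c3ccc(Cl)cc3)nc(-c3ccco3)c2)c1`, 27.1%
compound 2, `Oc1cccc(-c2cc(-c3cccc(Cl)c3)nc(-c3ccccn3)c2)c1`, 0.4%
compound 3, `Oc1cccc(-c2cc(-c3ccsc3)nc(-c3cccc(Cl)c3)c2)c1`, 26.2%

In an assay on isolated protein for inhibition of DNA topoisomerase 1 (Homo sapiens), with a stated time of 30 min, tested at 100 uM (on this read-out higher numbers stand for a stronger effect at the one concentration tested and lower numbers for a weaker effect), compound 3 gives 26.2%. Compound 3 stands second highest of the three numbers; its nearest neighbour is compound 1, which gives 27.1%, a gap within the scatter, and its furthest is compound 2, which gives 0.4%. Among the measured compounds shown here, the one step in this set, a number 25.8 percentage points higher from compound 2 to compound 3 (beyond the scatter), is the only one measured so far.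

Compound 4, `Oc1cccc(-c2cc(-c3cccc(Cl)c3)nc(-c3ccco3)c2)c1`, is not yet measured. It differs from compound 3 by furan-2-yl in place of thiophen-3-yl on an aromatic carbon. For the measured compounds named here, no measured step bears directly on this change, since the step from compound 2 to compound 3 concerns a different group. Compound 1 already carries furan-2-yl, though with its chloro on a different ring position, and its value and that of compound 3 lie within the scatter of each other. On that ground compound 4 is expected to give a value close to compound 3, with a number 0.2 percentage points lower from compound 3 to compound 4 (within the scatter) as the expected step, not beyond the scatter. The estimate for compound 4 is 26%, with a range from 10% to 42%.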

Compound 4, a percentage reported as inhibition, at one concentration (the size of the read-out at that concentration, not a potency): 5.5%
The estimate for compound 4 lay 20.5 percentage points above the measured number, and the stated range ends above it.
By their numbers in this assay, from the lowest: compounds 2 and 4 (each within the scatter of the next); then compounds 3 and 1 (each within the scatter of the next).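

At the place next to the ring nitrogen, furan-2-yl and thiophen-3-yl proved not to be interchangeable: in this assay the swap gives a number 20.7 percentage points lower from compound 3 to compound 4 (beyond the scatter) even though the two groups match in heavy-atom count, ring size and hydrogen-bond acceptor count. With the 3-chlorophenyl group kept, furan-2-yl and pyridin-2-yl are not told apart, as the change shows a number 5.1 percentage points higher from compound 2 to compound 4 (within the scatter) in this assay, so among compounds 2, 3 and 4 thiophen-3-yl alone stands apart at this place. Among the compounds shown here, the position of the chlorine also counts with furan-2-yl held fixed, a point no earlier step could show, since 3-chlorophenyl in place of 4-chlorophenyl gives a number 21.6 percentage points lower from compound 1 to compound 4 (beyond the scatter) and leaves compound 4 well apart from compound 1.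

Nothing given here accounts for why these groups differ at this place. From the compounds shown here alone, it remains open whether the difference belongs to thiophen-3-yl in particular or would extend to thiophen-2-yl, a plain phenyl or an amine such as morpholine at this place, and whether 4-chlorophenyl would have the same effect alongside thiophen-3-yl as it does alongside furan-2-yl.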